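This account rests on a few compounds, and the source may have more. Where it says the series, first, only, none or still open, it means among the compounds named here.

Compound 2 `CC(C)CCOc1cc(C(F)(F)F)ccc1CNC(=O)C(C)c1ccc(NS(C)(=O)=O)c(F)c1` gives 0.5 nM in an assay on CHO cells for antagonist activity at transient receptor potential cation channel subfamily V member 1 (Homo sapiens), read by FLIPR (a lower number here means a stronger inhibitor, a higher number a weaker inhibitor), the lowest of the two numbers at hand. Compound 1 `CCC1CCN(c2cc(C(F)(F)F)ccc2CNC(=O)C(C)c2ccc(NS(C)(=O)=O)c(F)c2)CC1` gives 0.7 nM in this assay, and the step of a 1.4-fold lower number from compound 1 to compound 2 (0.15 log units; within the scatter) lies within the scatter. Compound 3 `CC(C(=O)NCc1ccc(C(F)(F)F)cc1SCCCO)c1ccc(NS(C)(=O)=O)c(F)c1` carries the change ((3-hydroxypropyl)sulfanyl in place of isopentyloxy on an aromatic carbon). For the measured compounds named here, the step from compound 1 to compound 2 touched the same aromatic carbon and was within the scatter, so the change is expected to be tolerated, though the group that enters brings a hydroxyl that no measured compound shows. For compound 3 a modest rise is therefore expected, a 3.0-fold higher number from compound 2 to compound 3 (0.48 log units; beyond the scatter), giving an estimate of 1.5 nM with a range from 0.4 nM to 6 nM.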

Compound 3, inhibition constant: "not active" (no number reported)
The entry for compound 3 holds no number; no gap can be computed for the estimate.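

For the compounds shown here, compound 3 is entered as "not active" in this assay with no number, so no step from compound 2 to compound 3 can be read. Nothing measured here accounts for this entry. The compounds shown leave open whether the sulfur or the hydroxyl of (3-hydroxypropyl)sulfanyl lies behind it.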